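The compounds below may be only part of what the source reports. "The series", "measured", "known", "first", "only" and "open" are said of these compounds alone.

Of the compounds shown here, three have been measured so far. In an ADME assay on a cell-free system (plasma, Mus musculus) for metabolic stability, read by LC-MS, with a stated time of 60 min, tested at 10 uM (on this read-out higher numbers stand for a more stable compound and lower numbers for a less stable compound), compound 1 (`CC(C)[C@H](N)C(=O)N[C@@H](CCC(=O)C=[N+]=[N-])C(=O)OCc1c[nH]c2ccccc12`) gives 0%, compound 2 (`CCC(OC(=O)N[C@@H](CCC(=O)C=[N+]=[N-])C(=O)OC)OC(=O)C(C)(C)C`) gives 0% and compound 3 (`CCOC(=O)[C@H](CCC(=O)C=[N+]=[N-])NC(=O)OCc1oc(=O)oc1C`) gives 0%. Compound 3 therefore stands level with the other two, even though the three structures differ in several places. None of the three has any compound left at the end of the test, so the read-out does not separate them.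

The next compound, compound 4 (`Cc1oc(=O)oc1COC(=O)N[C@@H](CCC(=O)C=[N+]=[N-])C(=O)OC(C)C`), is compound 3 with one small edit: methyl in place of hydrogen on a saturated chain carbon bound to an oxygen next to a carbonyl group and a saturated chain carbon. Put simply, the ethoxycarbonyl group becomes an isopropoxycarbonyl group, and the rest of the structure stays the same. Within the data shown here, no two measured compounds differ in only one place, so the data do not show how large a step such an edit can produce in this assay. The expectation rests on compound 3 at 0%, which lies at the bottom of the scale, so any visible move can only be upward. The estimated step of a number 5 percentage points higher from compound 3 to compound 4 (within the scatter) is expected to stay within the usual scatter. For compound 4 the expected value is 5%, within an estimated range of 0% to 25%.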

Compound 4, percent of the compound remaining: 0%
Compound 4: middle estimate off by 5 percentage points, on the high side; the measured number falls inside the stated range.
By their numbers in this assay, from the lowest: compounds 1, 2, 3 and 4 (each within the scatter of the next).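

In this assay, among these compounds, this is the first step between two compounds that differ in one place, and it reads no change at the digits printed from compound 3 to compound 4 (within the scatter). At this position, on a saturated chain carbon bound to an oxygen, adding a methyl to turn ethoxycarbonyl into isopropoxycarbonyl does not bring the reading up from the bottom of the scale, so this one edit is not enough to leave compound measurable at the end of the test. Nothing available explains this result.

A reading at the bottom of the scale can hide real differences, so the step cannot show whether the edit changes how quickly the compound disappears before the end of the test. From the compounds shown here alone, it remains open whether a tert-butyl group or a longer chain at this position would leave any compound remaining, and a shorter test time would be needed to tell apart compounds that all end at the same reading.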